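Diaminoquinoxaline series: ether to benzylamine at the aryl position

The source may hold more compounds than are shown below. What is called first, only, known or untested is meant among the compounds shown, and "the series" means these compounds.

Measured so far:
compound 1 `Nc1cc(N)c2nc(-c3ccccc3)c(Sc3ccc(F)cc3)nc2c1` — 28200 nM
compound 2 `Nc1cc(N)c2nc(-c3ccccc3)c(Oc3ccc(F)cc3)nc2c1` — 81300 nM
compound 3 `CCOC(=O)[C@H](CCC(=O)O)NC(=O)c1ccc(Oc2nc3cc(N)cc(N)c3nc2-c2ccccc2)cc1` — 28800 nM

Three compounds on the shared core have numbers in a functional assay on HCT-116 cells (Homo sapiens) for inhibition, read by sulforhodamine B assay, with a stated time of 48 h; a lower number here means a stronger inhibitor of growth, a higher number a weaker inhibitor of growth. Compound 2 stands highest of the three; compound 1 sits lower at 28200 nM and compound 3 also sits lower at 28800 nM, both gaps beyond the scatter. Within the data shown here, the only single-point step available is a 2.9-fold higher number from compound 1 to compound 2 (0.46 log units; beyond the scatter), which shows that exchanging the sulfur link for the oxygen link costs potency on this core.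

Compound 4 `Nc1cc(N)c2nc(-c3ccccc3)c(NCc3ccc(F)cc3)nc2c1` is not yet measured. Its change from compound 2 is (4-fluorobenzyl)amino in place of 4-fluorophenoxy on an aromatic carbon. Among the measured compounds shown here, no measured pair covers a nitrogen link of this kind, and none covers a methylene spacer, so the expectation rests only on the general finding that the oxygen link of compound 2 is the weakest variant seen, while compound 1 and compound 3 both lie well below it. The step from compound 2 to compound 4 is therefore expected to move downward, modestly, with wide uncertainty: a 2.0-fold lower number from compound 2 to compound 4 (0.31 log units; beyond the scatter).

Compound 4 is estimated at 40000 nM in this assay, with a range from 12000 nM to 130000 nM.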

Compound 4, concentration for total growth inhibition: < 100000 nM
Compound 4 gave a limit, no number; the forecaster's own chance of this, stated with the estimate: 15%; the middle value does not contradict the limit.
By their numbers in this assay, from the lowest: compounds 1 and 3 (each within the scatter of the next); then compound 2.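

In this assay compound 4 gives < 100000 nM, which is a limit and not a number, so the steps to compound 4 from compound 1 and compound 2 cannot be read. The compounds shown leave open where (4-fluorobenzyl)amino on the shared core stands relative to 4-fluorophenoxy and (4-fluorophenyl)sulfanyl.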